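The compounds below may be only part of what the source reports. "The series", "measured", "known", "first", "only" and "open" are said of these compounds alone.

Compound 1 `COc1cccc(CCC(=O)Nc2nc3ccccc3c(=O)s2)c1` is one of two compounds for which a number has been recorded in an in vitro assay on cells for inhibition of Amine oxidase [flavin-containing] B (Homo sapiens), read by fluorescence and Amplex Red, with stated times of 30 min and 45 min; on this read-out lower numbers stand for stronger inhibition and higher numbers for weaker inhibition. In this assay compound 1 gives 95.3 nM, the higher of the two numbers. Going by the values given here, its nearest neighbour is compound 2 `O=C(CCCc1ccccc1)Nc1nc2sccc2c(=O)s1`, which in this assay gives 69.7 nM; the two values lie within the scatter of each other, so no order can be read between compound 1 and compound 2, and no step between them is computed.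

Compound 3 `O=C(CCCc1cccc(Cl)c1)Nc1nc2ccccc2c(=O)s1` has not been measured. It differs from compound 1 in one place: 3-chlorobenzyl in place of 3-methoxyphenyl on a saturated chain carbon, two bonds along the chain from a carbonyl carbon. The longer chain carrying a phenyl ring is also present in compound 2, whose value of 69.7 nM is no worse than that of compound 1, though compound 2 has a different core, so this gives only a rough hint.

On that basis the step from compound 1 to compound 3 is expected to be small, a 1.3-fold lower number from compound 1 to compound 3 (0.10 log units; within the scatter), and not clearly beyond the scatter in either direction. Compound 3 is therefore estimated at 75 nM, with a likely range from 25 nM to 220 nM.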

Compound 3, half-maximal inhibitory concentration: > 1000 nM
Compound 3: no number, only a limit; the forecaster's own chance of this, stated with the estimate: 5%; at least 13-fold (1.12 log units) between middle value and limit.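

In this assay compound 3 gives > 1000 nM, which is a limit of the assay and not a number. This is the first step shown on this saturated chain carbon, two bonds along the chain from a carbonyl carbon: exchanging 3-methoxyphenyl for 3-chlorobenzyl gives an at least 10-fold higher number from compound 1 to compound 3 (1.02 log units; beyond the scatter), so on the shared core this place does not accept every group of the same heavy-atom count. The step has a lower bound but no measured size, and its reading rests on this limit: the limit of > 1000 nM in this assay, at which 1 of the 3 values shown sits.

The change replaces methoxy with chlorine and phenyl with benzyl at once, so the compounds shown cannot say which of the two goes with the higher number; 3-chlorophenyl or 3-methoxybenzyl at this place would separate them. As far as these compounds go, how far compound 3 lies beyond its limit also stays open, as does whether the same change would have a similar effect on the core of compound 2.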